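The source may hold more compounds than are shown below. What is called first, only, known or untested is meant among the compounds shown, and "the series" means these compounds.

In a functional assay on A549/CDDP cells (Homo sapiens) for antiproliferative activity, read by MTT assay, with a stated time of 72 h (a lower number here means a stronger inhibitor, a higher number a weaker inhibitor), compound 1 `Cc1nc(C)c(/C=C/C(=O)/C=C/c2cccc(O)c2)nc1C` gives 3700 nM and compound 2 `COc1ccccc1/C=C/C(=O)/C=C/c1nc(C)c(C)nc1C` gives 4740 nM. These two numbers lie within the usual scatter of repeated measurements, so compound 2 stands alongside compound 1 and the assay does not separate them. The next structure is compound 3 `Cc1nc(C)c(/C=C/C(=O)/C=C/c2ccccc2)nc1C`, which differs from compound 2 in one place: hydrogen in place of methoxy on an aromatic carbon. In words, hydrogen stands in place of methoxy on an aromatic carbon. Going by the values given here, no measured pair shows what this kind of change does here, so any forecast remains loose. With so little data, no direction can be favoured, and no change beyond the scatter is expected. The expected step of a 1.2-fold lower number from compound 2 to compound 3 (0.07 log units; within the scatter) is therefore small. Compound 3 is estimated at 4000 nM, with an expected range from 1800 nM to 9000 nM.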

Compound 3, half-maximal inhibitory concentration: 11900 nM
Estimate against measurement, compound 3: 3.0-fold (0.47 log units) below; measured number above the stated range.
By their numbers in this assay, from the lowest: compounds 1 and 2 (each within the scatter of the next); then compound 3.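

In this assay the step on replacing methoxy, ortho to a large group, with hydrogen is a 2.5-fold higher number from compound 2 to compound 3 (0.40 log units; beyond the scatter), so this place on the aromatic ring is not indifferent to what it carries, and here the unsubstituted ring gives the weaker compound. Hydrogen in place of hydroxy on an aromatic carbon points the same way, with a 3.2-fold higher number from compound 1 to compound 3 (0.51 log units; beyond the scatter), and neither pair goes against this, though two pairs make only a small pattern. No measurement on hand explains why either group gives the lower number.

Going by these compounds, it remains open whether the oxygen matters or whether any group on this ring would serve. An amine, a chlorine atom or a longer ethoxy chain at the same aromatic carbon would help to separate these possibilities.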